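Xanthine series with pyrazole substituents at adenosine receptor A2b

The source may hold more compounds than are shown below. What is called first, only, known or untested is meant among the compounds shown, and "the series" means these compounds.

Measured so far:
compound 1 `CCCn1c(=O)c2nc(-c3cc(C)nn3CC)[nH]c2n(CCC)c1=O`: 2100 nM
compound 2 `CCCn1c(=O)c2nc(-c3cnn(Cc4cc(C(F)(F)F)ccc4Cl)c3)[nH]c2n(CCC)c1=O`: 22 nM

In an in vitro assay on HEK293 cells for displacement of a labelled ligand from adenosine receptor A2b (Homo sapiens) (a lower number here means a stronger inhibitor, a higher number a weaker inhibitor), compound 2 gives 22 nM, the lowest of the two numbers obtained; its nearest neighbour is compound 1, whose value in this assay is 2100 nM, a gap that lies well beyond the scatter. Going by the values given here, no pair of measured compounds differs in only one place, so no single step within the data can be quantified.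

Compound 3 `CCCn1c(=O)c2nc(-c3cnn(Cc4ccccc4OC)c3)[nH]c2n(CCC)c1=O` is the next member to be measured in this assay. The change from compound 2 is 2-methoxyphenyl in place of 2-chloro-5-(trifluoromethyl)phenyl on a saturated chain carbon bound to an aromatic nitrogen. The shared core and both propyl chains are unchanged. Among the compounds with values here, no measured step bears on this change, and the expectation is therefore uncertain; a modest rise in the number, beyond the scatter but well short of the gap to compound 1, is expected. The step from compound 2 to compound 3 is estimated as a 3.0-fold higher number from compound 2 to compound 3 (0.47 log units; beyond the scatter). For compound 3 the estimated value in this assay is 65 nM, with a range from 20 nM to 250 nM.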

Compound 3, inhibition constant: 37 nM
Beside the measured number, compound 3's estimate is 1.8-fold (0.24 log units) above it, and the stated range covers the measured number.
By their numbers in this assay, from the lowest: compounds 2 and 3 (each within the scatter of the next); then compound 1.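

Going by these compounds alone, on the saturated chain carbon bound to an aromatic nitrogen, 2-methoxyphenyl in place of 2-chloro-5-(trifluoromethyl)phenyl gives a 1.7-fold higher number from compound 2 to compound 3 (0.23 log units; within the scatter) in this assay as the first single-place step. Compound 3 carries neither chlorine nor fluorine, so at this position neither the chloro nor the trifluoromethyl group is required for a number within the scatter of that of compound 2. No supporting data bear on why this exchange leaves the number within the scatter.

Still open, as far as these compounds go, is whether the phenyl ring on this chain carbon can give way to a plain alkyl chain, and what an amine or a carboxylic acid on that ring would do to the number. From the compounds shown here alone, the effect of a longer chain in place of either propyl chain also remains open.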